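The compounds below may be only part of what the source reports. "The series", "measured", "known", "first", "only" and "open" are said of these compounds alone.

In a functional assay on MDA-MB-231 cells (Homo sapiens) for inhibition, read by MTT assay, with a stated time of 48 h (a higher number here means a weaker inhibitor, a lower number a stronger inhibitor), three amides on a shared core have been measured. Compound 1 `N#Cc1cccc(NC(=O)c2[nH]cnc2-c2nc3ccccc3[nH]2)c1` gives 24900 nM. Compound 3 `O=C(NC1CCC1)c1[nH]cnc1-c1nc2ccccc2[nH]1` gives 33800 nM. Compound 2 `CC(C)(C)NC(=O)c1[nH]cnc1-c1nc2ccccc2[nH]1` is reported only as a limit, > 40000 nM. Within the data shown here, the two exact numbers lie within the scatter of each other, the step being a 1.4-fold higher number from compound 1 to compound 3 (0.13 log units; within the scatter), so compound 3 stands level with the only other compound that has an exact number.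

Compound 4 `O=C(NC1CCCC1)c1[nH]cnc1-c1nc2ccccc2[nH]1` has not yet been measured. It differs from compound 3 by one change, cyclopentyl in place of cyclobutyl on an amide-type nitrogen.

Among the measured compounds shown here, the steps that bear on this are the other exchanges on the same nitrogen. Besides the step already given, they are an at least 1.6-fold higher number from compound 1 to compound 2 (0.20 log units; that floor lies within the scatter) and an at least 1.1-fold lower number from compound 2 to compound 3 (0.07 log units; that floor lies within the scatter). Both of these rest on a limit, so each gives only a floor, and neither floor goes beyond the scatter. With compound 3 at 33800 nM and no measured exchange at this nitrogen showing a step beyond the scatter, no step beyond the scatter is expected here. The expected step is a 1.1-fold lower number from compound 3 to compound 4 (0.05 log units; within the scatter). For compound 4 the estimated value is 30000 nM, with an expected range of 16000 nM to 48000 nM.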

Compound 4, half-maximal inhibitory concentration: 20600 nM
Beside the measured number, compound 4's estimate is 1.5-fold (0.16 log units) above it, and the stated range covers the measured number.
By their numbers in this assay, from the lowest: compounds 4, 1 and 3 (each within the scatter of the next). At a limit, above all of these: compound 2.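

In this assay, cyclopentyl in place of cyclobutyl on the amide-type nitrogen gives a 1.6-fold lower number from compound 3 to compound 4 (0.22 log units; within the scatter) and so stays within the scatter, which shows that this change of ring size, from a four-membered to a five-membered ring of carbon only, produces no readable difference in this assay. The exchange for a group of a different kind reads the same way: cyclopentyl in place of 3-cyanophenyl gives a 1.2-fold lower number from compound 1 to compound 4 (0.08 log units; within the scatter) and leaves compound 4 and compound 1 level. Compound 2 is known only as a limit, so the exchange of its tert-butyl for cyclopentyl gives an at least 1.9-fold lower number from compound 2 to compound 4 (0.28 log units; that floor lies within the scatter) as a floor, and even this widest step seen at the position does not go beyond the scatter: the limit of > 40000 nM in this assay, at which 1 of the 4 values shown sits.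

The compounds shown leave open whether any group on this nitrogen can move the number beyond the scatter in this assay at all. A cyclohexyl ring, a longer chain, or a ring carrying an amine or a carboxylic acid would test this, and changes elsewhere on the shared core remain equally unexplored here.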